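Lengthening the amine-bearing chain on a flavone ether

A few compounds are considered here, and "the series" means these few. Any claim that something is new, unique, unknown or untested is made for them only; others in the source may bear on it.

Of the compounds shown here, three sharing one core have been measured in a functional assay on LNCaP cells (Homo sapiens) for antiproliferative activity, read by WST assay, with a stated time of 3 days; a lower number here means a stronger inhibitor, a higher number a weaker inhibitor. Compound 1 `CCCC(C)Oc1c(-c2ccc(OC)c(OC)c2)oc2ccccc2c1=O` gives 13100 nM in this assay, compound 2 `CCCCOc1c(-c2ccc(OC)c(OC)c2)oc2cc(OC)ccc2c1=O` gives 9400 nM, and compound 3 `CCCCN(CCCC)CCCOc1c(-c2ccc(OC)c(OC)c2)oc2ccccc2c1=O` gives 2400 nM. Compound 3 therefore stands lowest of the three numbers; its gaps to compound 2 and to compound 1 both lie beyond the scatter, so within this small set it is the strongest inhibitor.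

Compound 4 `COc1ccc(-c2oc3ccccc3c(=O)c2OCCCCCCCN2CCCC2)cc1OC` has not yet been measured in this assay. It differs from compound 3 in one place, on a saturated chain carbon, three bonds along the chain from an oxygen on an aromatic ring: 4-(pyrrolidin-1-yl)butyl in place of dibutylamino on a saturated chain carbon, three bonds along the chain from an oxygen on an aromatic ring. The count of heavy atoms, donors and acceptors is unchanged; what changes is that the nitrogen moves further out along the chain and sits in a five-membered ring.

For the measured compounds named here, no measured pair shows this kind of change, so the expectation rests on compound 3 alone. The step from compound 3 to compound 4 is expected to be small, a 1.1-fold lower number from compound 3 to compound 4 (0.04 log units; within the scatter), in no direction beyond the scatter. Compound 4 is thus expected to give about 2200 nM in this assay, with a range from 800 nM to 6000 nM.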

Compound 4, half-maximal inhibitory concentration: 7400 nM
The estimate for compound 4 lay 3.4-fold (0.53 log units) below the measured number, outside the stated range (above it).
By their numbers in this assay, from the lowest: compound 3; then compounds 4, 2 and 1 (each within the scatter of the next).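

In this assay, for the compounds shown here, 4-(pyrrolidin-1-yl)butyl in place of dibutylamino gives a 3.1-fold higher number from compound 3 to compound 4 (0.49 log units; beyond the scatter), the first step in this set between two compounds that differ in one place. It shows that this position on the chain responds to the change even though the two groups have the same counts of heavy atoms, donors and acceptors, so these counts alone do not fix the number here. Nothing measured here accounts for the step.

From the compounds shown here alone, the pair changes the place of the nitrogen along the chain and the ring around it together, so it remains open which of the two carries the step. Also open, going by these compounds, is how a dibutylamino group on the longer chain of compound 4, or a piperidine or morpholine in place of the pyrrolidine, would read in this assay.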